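Ring-to-chain swap at the aryl substituent

The compounds below may be only part of what the source reports. "The series", "measured", "known", "first", "only" and "open" are said of these compounds alone.

Measured compounds:
compound 1 `CC(C(=O)NCc1ccc(C(F)(F)F)cc1N1CCCC1)c1ccc(NS(C)(=O)=O)c(F)c1`, 2.3 nM
compound 2 `CC(C(=O)NCc1ccc(C(F)(F)F)cc1N1CCCCCC1)c1ccc(NS(C)(=O)=O)c(F)c1`, 1.6 nM
compound 3 `CC(C(=O)NCc1ccc(C(F)(F)F)cc1OC1CCCCC1)c1ccc(NS(C)(=O)=O)c(F)c1`, 0.7 nM

In an assay on CHO cells for antagonist activity at transient receptor potential cation channel subfamily V member 1 (Homo sapiens), read by FLIPR (a lower number here means a stronger inhibitor, a higher number a weaker inhibitor), compound 1 gives the highest of the three numbers; compound 2 sits within the scatter of it, compound 3 further away. Compound 4 `CCCCCCSc1cc(C(F)(F)F)ccc1CNC(=O)C(C)c1ccc(NS(C)(=O)=O)c(F)c1` differs from compound 1 in one place: hexylsulfanyl in place of pyrrolidin-1-yl on an aromatic carbon. Among the measured compounds shown here, two measured steps bear on this. a 1.4-fold lower number from compound 1 to compound 2 (0.16 log units; within the scatter), so enlarging the ring changes little. a 3.3-fold lower number from compound 1 to compound 3 (0.52 log units; beyond the scatter), a modest gain when cyclohexyloxy stands in place of pyrrolidin-1-yl. For the measured compounds named here, no measured step opens the ring into a chain or introduces a sulfur link, so only a small step is expected, if any, and more likely downward than upward. The expected step is a 1.5-fold lower number from compound 1 to compound 4 (0.19 log units; within the scatter). Compound 4 is estimated at 1.5 nM, range 0.5 nM to 5 nM.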

Compound 4, inhibition constant: 1.8 nM
Beside the measured number, compound 4's estimate is 1.2-fold (0.08 log units) below it, within the range that was stated.
By their numbers in this assay, from the lowest: compound 3; then compounds 2, 4 and 1 (each within the scatter of the next).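

In this assay this position accepts an open chain in place of a ring: a 1.3-fold lower number from compound 1 to compound 4 (0.11 log units; within the scatter) and a 1.1-fold higher number from compound 2 to compound 4 (0.05 log units; within the scatter) both lie within the scatter, so among these compounds neither a ring nor a nitrogen link is required. Cyclohexyloxy is the exception, with a 2.6-fold higher number from compound 3 to compound 4 (0.41 log units; beyond the scatter) as the one step here beyond the scatter. No measured evidence accounts for that gap.

Because the ring and the linking atom change together between compound 3 and compound 4, their contributions remain unseparated. Hexyloxy and cyclohexylsulfanyl would separate them, while a shorter chain such as butylsulfanyl would test chain length.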